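The source may hold more compounds than are shown below. What is called first, only, known or untested is meant among the compounds shown, and "the series" means these compounds.

Going by the values given here, compound 2 `O=C(CCN1CCN(c2ccnc3cc(Cl)ccc23)CC1)N/N=C/c1ccccc1O` gives 83.2% in a physicochemical assay for inhibition, read by spectrophotometry, with a stated time of 24 h, tested at 2.5 mM (on this read-out higher numbers stand for more inhibition at the one concentration tested (going by the name of the read-out) and lower numbers for less inhibition), the higher of the two numbers measured so far; compound 1 `COc1cc(/C=N/NC(=O)CCN2CCN(c3ccnc4cc(Cl)ccc34)CC2)ccc1O` gives 50.7%, and the step of a number 32.5 percentage points higher from compound 1 to compound 2 (beyond the scatter) is large. Compound 3 `CC(C)c1ccc(/C=N/NC(=O)CCN2CCN(c3ccnc4cc(Cl)ccc34)CC2)cc1` differs from compound 2 by 4-isopropylphenyl in place of 2-hydroxyphenyl on a carbon with a double bond to nitrogen. Among the compounds with values here, no measured step strips the hydroxyl from this ring altogether; the one step available, which only rearranged the oxygen substituents on it, was large, so a sizeable move downward is anticipated rather than none. Compound 3 is expected to give about 45%, within 25% to 70%, an estimated step of a number 38.2 percentage points lower from compound 2 to compound 3 (beyond the scatter).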

Compound 3, a percentage reported as inhibition, at one concentration (the size of the read-out at that concentration, not a potency): 94%
For compound 3 the middle estimate is 49 percentage points below the measured one; the measured number lies above the stated range.
By their numbers in this assay, from the lowest: compound 1; then compound 2; then compound 3.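

In this assay, 4-isopropylphenyl on a carbon with a double bond to nitrogen brings a number 10.8 percentage points higher from compound 2 to compound 3 (beyond the scatter) and a number 43.3 percentage points higher from compound 1 to compound 3 (beyond the scatter) with no hydroxyl on the ring. A hydroxyl at this position, carried by both compound 1 and compound 2, is therefore not required for a high number, which the earlier pair could not show. Nothing available explains this result.

Going by these compounds, whether the isopropyl group itself matters remains open. So does the outcome with a carboxylic acid or an amine on this ring.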